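The source may report more compounds than this note shows. Statements on the series, on what has been measured and on what is new or still open speak of the compounds shown alone.

Measured so far in a functional assay on HeLa cells (Homo sapiens) for inhibition, read by MTT assay, with a stated time of 24 h, tested at 5 uM; on this read-out lower numbers stand for less inhibition of growth and higher numbers for more inhibition of growth at the one concentration tested:
compound 1, `CS(=O)(=O)c1ccc(-c2cnc3[nH]cc(-c4nnc(-c5ccc(Cl)cc5)o4)c(=O)c3c2)cc1`: 1.07%
compound 2, `N#Cc1ccc(-c2cnc3[nH]cc(-c4nnc(-c5ccc(Cl)cc5)o4)c(=O)c3c2)cc1`: 4.8%

Compound 1 stands lowest of these two numbers; its nearest neighbour is compound 2, reached by a number 3.7 percentage points higher from compound 1 to compound 2 (within the scatter). Compound 3, `CS(=O)(=O)c1ccc(-c2cnc3[nH]cc(-c4nnc(-c5ccc(F)cc5)o4)c(=O)c3c2)cc1`, differs from compound 1 by fluoro in place of chloro on an aromatic carbon. Going by the values given here, no measured step concerns this halogen exchange; the only measured step, from compound 1 to compound 2, alters another group and stays within the scatter. Compound 3 is therefore expected to show no step beyond the scatter, a number 0.9 percentage points higher from compound 1 to compound 3 (within the scatter). Compound 3 is estimated at 2%, with a range from -8% to 12%.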

Compound 3, percent growth inhibition at one concentration: 8.47%
Compound 3: the middle estimate sits 6.5 percentage points below what was measured; low and high end bracket the measured number.
By their numbers in this assay, from the lowest: compounds 1, 2 and 3 (each within the scatter of the next).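

In this assay, going by these compounds alone, the exchange of 4-chlorophenyl for 4-fluorophenyl gives a number 7.4 percentage points higher from compound 1 to compound 3 (within the scatter), the first reading at this position. At the one concentration tested, these two halogens on the ring therefore cannot be told apart. Nothing available bears on this result.

The compounds shown leave open whether an amine, a carboxylic acid or a longer chain in place of the halogen would give a step beyond the scatter. They also leave open how the fluoro compound would read with the cyano group in place of methylsulfonyl.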